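Aryl replacement at the terminal position of the imidazole series

The source may report more compounds than this note shows. Statements on the series, on what has been measured and on what is new or still open speak of the compounds shown alone.

Measured compounds:
- compound 1 `CCC(C)(C)Cc1c[nH]c(CCc2ccc(-c3ccncc3)cc2)n1`: 101 nM
- compound 2 `c1ccc(-c2ccc(CCc3nc(CC4CCCC4)c[nH]3)cc2)nc1`: 177 nM
- compound 3 `CCC(C)(C)Cc1c[nH]c(CCc2ccc(-c3cnccn3)cc2)n1`: 51 nM

All three numbers come from an in vitro assay on CHO cells for displacement of a labelled ligand from Bombesin receptor subtype-3 (Homo sapiens), read by scintillation counting, with a stated time of 2 h; on this read-out higher numbers stand for weaker inhibition and lower numbers for stronger inhibition. Compound 3 holds the lowest of the three: compound 1 sits close to it, since a 2.0-fold lower number from compound 1 to compound 3 (0.30 log units; within the scatter), whereas compound 2 sits further off, beyond the scatter. Compound 2 also differs from the others at the opposite end of the shared core, so its gap to compound 3 cannot be read as the effect of the terminal ring alone.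

Compound 4 `CCC(C)(C)Cc1c[nH]c(CCc2ccc(N3CCCCC3)cc2)n1` follows from compound 3 by one change: piperidin-1-yl in place of pyrazin-2-yl on an aromatic carbon.

Going by the values given here, the only measured step at this position is the one from compound 1 to compound 3, in which one six-membered aromatic ring with two hetero atoms replaced another with one, and it stayed within the scatter. Among the compounds with values here, no measured pair swaps an aromatic ring for a non-aromatic one, so the step to compound 4 has no precedent in the data. Given the flat response seen in a 2.0-fold lower number from compound 1 to compound 3 (0.30 log units; within the scatter), the expected step of a 2.4-fold higher number from compound 3 to compound 4 (0.37 log units; beyond the scatter) is set near zero, with a wide range to cover the untested kind of change. Compound 4 is thus estimated at 120 nM, between 30 nM and 500 nM.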

Compound 4, half-maximal inhibitory concentration: 28 nM
The estimate for compound 4 lay 4.3-fold (0.63 log units) above the measured number; measured number below the stated range.
By their numbers in this assay, from the lowest: compounds 4, 3, 1 and 2 (each within the scatter of the next, the first and the last beyond it).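

At this position, on an aromatic carbon para to a large group, a non-aromatic ring is accepted in this assay: with a 1.8-fold lower number from compound 3 to compound 4 (0.26 log units; within the scatter), piperidin-1-yl, a six-membered non-aromatic ring with 1 hetero atom, cannot be told apart from pyrazin-2-yl, a six-membered aromatic ring with 2 hetero atoms. Aromaticity of the terminal ring is therefore not required for binding in this series, which the swap between two aromatic rings could not show. Going by these compounds alone, the position is also not wholly flat, since a 3.6-fold lower number from compound 1 to compound 4 (0.56 log units; beyond the scatter) is the first step here beyond the scatter, though a modest one, while compound 3 stays within the scatter of both compound 1 and compound 4, and no supporting data bear on the reason for this result.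

Still open, going by these compounds, is how far this tolerance extends, for instance to morpholin-4-yl, to an open-chain amine such as dimethylamino, or to a carboxylic acid on the same aromatic carbon. Also open, on these data alone, is whether piperidin-1-yl behaves the same way when the other end of the shared core carries the group found in compound 2.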